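A Smaller Amine in Place of Benzylamino

The compounds below may be only part of what the source reports. "The series", "measured", "known", "first", "only" and "open" are said of these compounds alone.

Of the compounds shown here, two built on a shared core have been tested in a functional assay on MCF7 cells (Homo sapiens) for inhibition, read by sulforhodamine B assay; a lower number here means a stronger inhibitor, a higher number a weaker inhibitor. Compound 1 `O=C1C(NC2CC2)=CC(=O)c2c1nc1n2[C@H]2OC[C@@H](O)[C@H]2OC1` reaches only a limit of > 16000 nM in this assay. Compound 2 `O=C1C=C(NCc2ccccc2)C(=O)c2c1nc1n2[C@H]2OC[C@@H](O)[C@H]2OC1` likewise reaches only a limit of > 8000 nM in this assay. Among the compounds with values here, compound 2 therefore stands at a limit, and the single further value shown, that of compound 1, is a limit as well the limit of > 16000 nM in this assay, at which 1 of the 2 values shown sits (the limit of > 8000 nM in this assay, at which 1 of the 2 values shown sits); neither is a number from which a step could be measured, and no step between compound 1 and compound 2 is recorded.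

Compound 3 `O=C1C=C(N2CCC2)C(=O)c2c1nc1n2[C@H]2OC[C@@H](O)[C@H]2OC1` has not yet been measured. It differs from compound 2 in one place: azetidin-1-yl in place of benzylamino on a double-bonded ring carbon. Within the data shown here, with no measured step available, no step of any particular size can be drawn from the data, and compound 3 is expected to sit at a limit again, the step from compound 2 staying within the scatter, as a step that the limit leaves unreadable from compound 2 to compound 3. For compound 3 the estimate in this assay is 20000 nM, with a range from 6000 nM to 80000 nM.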

Compound 3, half-maximal inhibitory concentration: > 16000 nM
Compound 3: a limit, no number; the forecaster's own chance of this, stated with the estimate: 75%; the middle value is on the limit's open side.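

In this assay, within the data shown here, compound 2 and compound 3 both stand at limits rather than numbers, so no step between them can be read. The compounds shown leave open how strongly any of them inhibits, and whether azetidin-1-yl in place of benzylamino makes any difference at all.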